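Benzothiazole-indole semicarbazones: breast cancer cell cytotoxicity notes

The source may report more compounds than this note shows. Statements on the series, on what has been measured and on what is new or still open speak of the compounds shown alone.

Measured so far in a functional assay on MDA-MB-231 cells (Homo sapiens) for cytotoxicity, read by MTT assay, with a stated time of 72 h; a lower number here means a stronger inhibitor, a higher number a weaker inhibitor:
compound 1 `CN(C)Cc1ccc2nc(NC(=O)N/N=C/c3c[nH]c4ccccc34)sc2c1` gives 1190 nM;
compound 2 `CCN(CC)Cc1ccc2nc(NC(=O)N/N=C/c3cn(Cc4ccc(Cl)cc4)c4ccccc34)sc2c1` gives 2570 nM;
compound 3 `CN(C)Cc1ccc2nc(NC(=O)N/N=C/c3cn(Cc4ccc(Cl)cc4)c4ccccc34)sc2c1` gives 880 nM.

Compound 2 carries the highest number of the three. Between compound 3 and compound 2 the cores differ by diethylamino in place of dimethylamino on a saturated chain carbon bound to an aromatic carbon, and the step of a 2.9-fold lower number from compound 2 to compound 3 (0.47 log units; beyond the scatter) is the only change here that goes beyond the scatter.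

Compound 4 `CCN(CC)Cc1ccc2nc(NC(=O)N/N=C/c3c[nH]c4ccccc34)sc2c1` is not yet measured. It differs from compound 2 by hydrogen in place of 4-chlorobenzyl on an aromatic nitrogen. The same change, made between measured compounds, is hydrogen in place of 4-chlorobenzyl on an aromatic nitrogen; since the two place descriptions read alike, this is the same change, and it gave a 1.4-fold higher number from compound 3 to compound 1 (0.13 log units; within the scatter), a step within the scatter.

Among the compounds with values here, for compound 4 a step of about a 1.3-fold higher number from compound 2 to compound 4 (0.11 log units; within the scatter) is expected, resting on the single earlier instance a 1.4-fold higher number from compound 3 to compound 1 (0.13 log units; within the scatter) in compound 3 and compound 1, so that the number for compound 4 is expected to sit near that of compound 2, perhaps somewhat higher. The estimate for compound 4 in this assay is 3300 nM, with a range from 1500 nM to 7500 nM.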

Compound 4, half-maximal inhibitory concentration: 1900 nM
Beside the measured number, compound 4's estimate is 1.7-fold (0.24 log units) above it, within the range that was stated.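

Notes on carrying the two changes across the series, in this assay: hydrogen in place of 4-chlorobenzyl on the aromatic nitrogen gives a 1.4-fold lower number from compound 2 to compound 4 (0.13 log units; within the scatter), and the two instances of this change do not differ beyond the scatter: the same change on two cores in this assay, a 1.4-fold higher number (0.13 log units; within the scatter) from compound 3 to compound 1 and a 1.4-fold lower number (0.13 log units; within the scatter) from compound 2 to compound 4, 1.8-fold (0.26 log units) apart, within the scatter of two such steps. Diethylamino in place of dimethylamino gives a 1.6-fold higher number from compound 1 to compound 4 (0.20 log units; within the scatter) on the core without 4-chlorobenzyl, a step within the scatter where the instance on the core with 4-chlorobenzyl lies beyond it, yet the two instances still do not differ beyond the scatter: the same change on two cores in this assay, a 2.9-fold lower number (0.47 log units; beyond the scatter) from compound 2 to compound 3 and a 1.6-fold lower number (0.20 log units; within the scatter) from compound 4 to compound 1, 1.8-fold (0.26 log units) apart, within the scatter of two such steps. This shows that each change reads compatibly on these two cores, but with only two instances of each it does not show that the steps are equal, nor that either would carry to a further core.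

The compounds shown leave open how a plain benzyl or a methyl on the aromatic nitrogen would read in this assay. They also leave open a cyclic amine such as morpholine or piperidine in place of the dialkylamino group on the chain carbon.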